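The source may hold more compounds than are shown below. What is called first, only, known or untested is meant among the compounds shown, and "the series" means these compounds.

Of the compounds shown here, three sharing one core have been measured in an assay on CHO cells for displacement of a labelled ligand from adenosine receptor A3 (Homo sapiens), read by scintillation counting, with a stated time of 3 h; a lower number here means a stronger inhibitor, a higher number a weaker inhibitor. Compound 1 `Nc1nc(-c2cccc(CO)c2)nc2sc(-c3ccccc3)nc12` gives 3.7 nM, compound 2 `Nc1nc(-c2ccc(CO)cc2)nc2sc(-c3ccccc3)nc12` gives 8.2 nM, and compound 3 `COc1cccc(-c2nc(N)c3nc(-c4ccccc4)sc3n2)c1` gives 35.6 nM. Compound 2 thus stands second highest of the three numbers: the step of a 2.2-fold higher number from compound 1 to compound 2 (0.35 log units; beyond the scatter) is small, the step of a 4.3-fold higher number from compound 2 to compound 3 (0.64 log units; beyond the scatter) is larger, and the step of a 9.6-fold higher number from compound 1 to compound 3 (0.98 log units; beyond the scatter) spans both together. Compound 4 `Nc1nc(-c2ccc(CO)cc2)nc2sc(-c3ccco3)nc12` has not yet been measured. It differs from compound 2 in one place: furan-2-yl in place of phenyl on an aromatic carbon. None of the three measured steps touches this part of the structure; each of them alters a different region of the molecule, so they give no direct guide to what this exchange does. Within the data shown here, with no measured precedent, the step from compound 2 to compound 4 is expected to be a 1.4-fold lower number from compound 2 to compound 4 (0.14 log units; within the scatter), which lies within the usual scatter. On that basis compound 4 is expected to give 6 nM in this assay, with a range from 2 nM to 25 nM.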

Compound 4, inhibition constant: 3.58 nM
Compound 4: middle estimate off by 1.7-fold (0.22 log units), on the high side; low and high end bracket the measured number.
By their numbers in this assay, from the lowest: compounds 4 and 1 (each within the scatter of the next); then compound 2; then compound 3.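

Among these compounds, this is the first look at the aromatic carbon next to the ring nitrogen and next to the ring sulfur, and in this assay furan-2-yl in place of phenyl brings a 2.3-fold lower number from compound 2 to compound 4 (0.36 log units; beyond the scatter). The phenyl group is therefore not needed for a low number here: a five-membered aromatic ring with one oxygen serves at least as well on this core, and the step is modest but beyond the scatter. Nothing available explains why this exchange lowers the number.

As far as these compounds go, whether furan-2-yl has the same effect alongside the 3-(hydroxymethyl)phenyl group of compound 1 or the 3-methoxyphenyl group of compound 3 remains open. So does how other groups would behave at this position, such as thiophen-2-yl, a pyridine ring or a simple methyl.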